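Removing One Methoxy Group, Seen Twice

A few compounds are considered here, and "the series" means these few. Any claim that something is new, unique, unknown or untested is made for them only; others in the source may bear on it.

Of the compounds shown here, three have been measured in a functional assay on M14 cells (Homo sapiens) for inhibition, read by sulforhodamine B assay, with a stated time of 48 h; on this read-out higher numbers stand for weaker inhibition of growth and lower numbers for stronger inhibition of growth. Compound 3 `COc1ccc(-c2[nH]c3ccc(OC)cc3c2C=C(C#N)C#N)cc1` gives 308 nM. Compound 1 `COc1ccc2[nH]c(-c3ccccc3)c(C=C(C#N)C#N)c2c1` is its close relative: in this assay compound 1 gives 2300 nM. The difference between them is hydrogen in place of methoxy on an aromatic carbon, and the step it made is a 7.5-fold higher number from compound 3 to compound 1 (0.87 log units; beyond the scatter). Compound 2 `COc1ccc(-c2[nH]c3ccc(OC)cc3c2/C=C(\C#N)S(=O)(=O)c2ccccc2)cc1` carries a phenylsulfonyl group and a single nitrile where compound 3 carries two nitriles; in this assay compound 2 gives 500 nM. The difference between the cores of compound 2 and compound 3 is not broken down here, and their two numbers lie within the scatter of each other, so no order can be read from them.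

Compound 4 `COc1ccc2[nH]c(-c3ccccc3)c(/C=C(\C#N)S(=O)(=O)c3ccccc3)c2c1` has not yet been measured. It differs from compound 2 as hydrogen in place of methoxy on an aromatic carbon, which matches the difference between compound 3 and compound 1 word for word in what leaves, what enters and where it sits, so it is the same change, made on a second core. Compound 4 is expected to show a step of similar size, a 6.0-fold higher number from compound 2 to compound 4 (0.78 log units; beyond the scatter), because the same change gave a 7.5-fold higher number from compound 3 to compound 1 (0.87 log units; beyond the scatter). On that basis compound 4 is estimated at 3000 nM in this assay, with an expected range from 1000 nM to 10000 nM.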

Compound 4, concentration for 50% growth inhibition: 3700 nM
For compound 4 the middle estimate is 1.2-fold (0.09 log units) below the measured one; measured number inside the range.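

Replacing the 4-methoxyphenyl group with phenyl in this assay gave a 7.4-fold higher number from compound 2 to compound 4 (0.87 log units; beyond the scatter), so growth inhibition is weaker without the methoxy group on this second core too. The change carried over from one core to the other with almost the same size, and neither pair shown goes against this: the same change on two cores in this assay, a 7.5-fold higher number (0.87 log units; beyond the scatter) from compound 3 to compound 1 and a 7.4-fold higher number (0.87 log units; beyond the scatter) from compound 2 to compound 4, 1.0-fold (0.00 log units) apart, within the scatter of two such steps This is still only two pairs, one change and one cell line, so it shows neither why the methoxy group matters nor whether the same step would appear on a third core or in other cells.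

At this place on the ring, the compounds shown carry only methoxy or hydrogen, so it remains open whether a longer chain such as ethoxy, a hydroxyl group, a fluorine atom or an amine would behave like methoxy, like hydrogen or like neither. All four compounds also share the second methoxy group on the core, which leaves open what would happen if that group were replaced by hydrogen or a carboxylic acid.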